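The source may report more compounds than this note shows. Statements on the series, on what has been measured and on what is new or still open speak of the compounds shown alone.

Working notes on the series. Compound 1 `S=C(N/N=C/c1cccs1)Nc1ccc(Cl)cc1`, compound 2 `S=C(N/N=C/c1cccs1)Nc1cccnc1` and compound 3 `Cc1ccc(NC(=S)N/N=C/c2cccs2)cc1` have been read in a functional assay on 786-0 cells (Homo sapiens) for inhibition, read by sulforhodamine B assay, with a stated time of 48 h; on this read-out higher numbers stand for weaker inhibition of growth and lower numbers for stronger inhibition of growth. Compound 1 gives 7400 nM, compound 2 gives 5600 nM and compound 3 gives 19500 nM. Compound 3 thus has the highest of the three numbers and is the weakest inhibitor of growth so far.

The next structure is compound 4 `CCc1ccc(NC(=S)N/N=C/c2cccs2)cc1`, which turns the methyl of compound 3 into ethyl: methyl in place of hydrogen on a saturated chain carbon bound to an aromatic carbon. This is methyl in place of hydrogen on a saturated chain carbon bound to an aromatic carbon.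

For the measured compounds named here, only one measured step bears on this change: a 2.6-fold higher number from compound 1 to compound 3 (0.42 log units; beyond the scatter), a modest step with methyl in place of chloro on an aromatic carbon. That step swaps a different group at a different kind of place, so it gives no firm direction here. No change on a saturated chain carbon has been measured yet.

The expected result in this assay is therefore no step beyond the scatter. The estimated step is a 1.3-fold lower number from compound 3 to compound 4 (0.11 log units; within the scatter). Compound 4 is estimated at 15000 nM, with an expected range of 7000 nM to 32000 nM.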

Compound 4, concentration for 50% growth inhibition: 82600 nM
Beside the measured number, compound 4's estimate is 5.5-fold (0.74 log units) below it; the whole stated range lies below it.
By their numbers in this assay, from the lowest: compounds 2 and 1 (each within the scatter of the next); then compound 3; then compound 4.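

In this assay, for the compounds shown here, lengthening methyl to ethyl gives a 4.2-fold higher number from compound 3 to compound 4 (0.63 log units; beyond the scatter); this is the first change read on a saturated chain carbon bound to an aromatic carbon, and a single added carbon there moves the number beyond the scatter. Set against the chloro compound, the ethyl compound gives an 11-fold higher number from compound 1 to compound 4 (1.05 log units; beyond the scatter), a large step, so among the chloro, methyl and ethyl compounds the number rises in that order, and inhibition of growth weakens with it. Nothing at hand bears on why the added carbon has this effect.

The compounds shown leave open whether propyl or a longer chain would raise the number further. They also leave open whether a hydroxyl on the ethyl chain, or an amine in its place, would bring the number back towards that of compound 3.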